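From 2,6-dichlorobenzyl to 2,6-difluorobenzyl

The compounds below may be only part of what the source reports. "The series", "measured", "known", "first", "only" and "open" are said of these compounds alone.

Measured compounds:
- compound 1 `Cc1c(Cc2c(F)cccc2F)nc(SCc2ccccn2)[nH]c1=O`: > 70000 nM
- compound 2 `Cc1c(Cc2c(Cl)cccc2Cl)nc(SCC(=O)c2ccc(F)cc2)[nH]c1=O`: > 57000 nM

Both compounds were tested in an ADME assay on MT4 cells (Homo sapiens) for cytotoxicity, read by MTT assay; on this read-out lower numbers stand for higher toxicity in this test and higher numbers for lower toxicity in this test. Compound 2 has no exact number, only the limit > 57000 nM. Compound 1 is also reported only as a limit, > 70000 nM. These two results therefore cannot be ranked.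

Compound 3 `Cc1c(Cc2c(F)cccc2F)nc(SCC(=O)c2ccc(F)cc2)[nH]c1=O` has 2,6-difluorophenyl in place of the 2,6-dichlorophenyl of compound 2, on a saturated chain carbon bound to an aromatic carbon: 2,6-difluorophenyl in place of 2,6-dichlorophenyl on a saturated chain carbon bound to an aromatic carbon. Compound 1 carries the same 2,6-difluorophenyl, and its result is the limit > 70000 nM. Within the data shown here, no measured step shows what this change does in this assay, so no shift beyond the usual scatter is expected. The expected change is a step that the limit leaves unreadable from compound 2 to compound 3. The estimated value for compound 3 is 60000 nM, with an expected range of 25000 nM to 100000 nM.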

Compound 3, half-maximal cytotoxic concentration: > 62000 nM
Compound 3 gave a limit, no number; the forecaster's own chance of this, stated with the estimate: 80%; middle value at least 1.0-fold (0.01 log units) away from the limit.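

Compound 3 is reported only as a limit, and neither the step from compound 2 to compound 3 nor the step from compound 1 to compound 3 can be read. The compounds shown leave open whether 2,6-difluorophenyl in place of 2,6-dichlorophenyl changes the result in this assay at all.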